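Sulfonamide nitrogen demethylation at the anilide position

The source may report more compounds than this note shows. Statements on the series, on what has been measured and on what is new or still open speak of the compounds shown alone.

Measured so far in a functional assay on the whole organism for inhibition, with Mus musculus as the target; on this read-out lower numbers stand for an effect already at smaller amounts and higher numbers for an effect only at larger amounts of compound:
compound 1 `CCN1CCCC1CNC(=O)c1cc(N(C)S(=O)(=O)N(C)C)c(Cl)cc1OC`: 31.8 mg/kg
compound 2 `CCN1CCCC1CNC(=O)c1cc(NS(C)(=O)=O)c(Cl)cc1OC`: 9.1 mg/kg
compound 3 `CCN1CCCC1CNC(=O)c1cc(NS(=O)(=O)NC)c(Cl)cc1OC`: > 50 mg/kg (a limit, not a number)

Among the compounds with values here, compound 3 is the one member of the series for which this assay returned only a limit; it stands at the limit of > 50 mg/kg in this assay, at which 1 of the 3 values shown sits. Compound 2 gives the lowest number of the three, and the gap an at least 5.4-fold higher number from compound 2 to compound 3 (0.73 log units; beyond the scatter) is beyond the scatter, while an at least 1.5-fold higher number from compound 1 to compound 3 (0.19 log units; that floor lies within the scatter) has a floor that lies within it.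

Compound 4 `CCN1CCCC1CNC(=O)c1cc(NS(N)(=O)=O)c(Cl)cc1OC` differs from compound 3 by hydrogen in place of methyl on a sulfonamide nitrogen. Within the data shown here, two measured steps touch the same sulfonyl-bound region. Going an at least 1.5-fold higher number from compound 1 to compound 3 (0.19 log units; that floor lies within the scatter) removes two methyls from the sulfamoyl and anilide nitrogens together and stays, at least at its floor, within the scatter. Going an at least 5.4-fold higher number from compound 2 to compound 3 (0.73 log units; beyond the scatter) replaces methyl by methylamino on the sulfonyl sulfur and the number rises beyond the scatter. Among the measured compounds shown here, neither step isolates the single methyl that leaves here, and the only direct neighbour, compound 3, is itself a limit, so the expected step is small and of uncertain sign.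

Compound 4 is therefore expected to give about 60 mg/kg, within 25 mg/kg to 150 mg/kg, most likely again at or near the limit. The expected step is a step that the limit leaves unreadable from compound 3 to compound 4, within the scatter.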

Compound 4, dose for half-maximal effect: > 50 mg/kg
Compound 4: no number, only a limit (the forecaster's own chance of this, stated with the estimate: 55%); the middle value lies beyond the limit too.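

On the sulfonyl sulfur, amino in compound 4 behaves as methylamino does in compound 3, and in this assay both compounds reach only the limit of the assay: the limit of > 50 mg/kg in this assay, at which 2 of the 4 values shown sit.

Measured against the methanesulfonamido group of compound 2, amino gives an at least 5.4-fold higher number from compound 2 to compound 4 (0.73 log units; beyond the scatter), so the rise from the methyl on the sulfonyl sulfur now holds for two nitrogen-bound replacements and does not depend on the methyl of methylamino. The other readable step, an at least 1.5-fold higher number from compound 1 to compound 4 (0.19 log units; that floor lies within the scatter), has a floor within the scatter and fixes no order, while the step that takes the methyl off the sulfonamide nitrogen cannot be read, with a limit at both ends.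

Which part of the (dimethylsulfamoyl)(methyl)amino group keeps compound 1 clear of the limit stays open, as the compounds shown do not separate its methyl groups. Also open, on these data alone, is how an ethyl group or a longer chain on the sulfonyl sulfur, in place of the methyl of compound 2, would read in this assay.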